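This account rests on a few compounds, and the source may have more. Where it says the series, first, only, none or still open, it means among the compounds named here.

Compound 1 `O=C1c2ccccc2C(=O)N1CCOC(=S)N(C(=O)c1ccc(Cl)c([N+](=O)[O-])c1)c1ccc(Cl)cc1`: 48000 nM
Compound 2 `Cc1cc(C(=O)N(C(=S)OCCN2C(=O)c3ccccc3C2=O)c2ccc(Cl)cc2)ccc1Br`: 18000 nM
Compound 3 `Cc1ccc(N(C(=O)c2ccc(Cl)c([N+](=O)[O-])c2)C(=S)OCCN2C(=O)c3ccccc3C2=O)cc1`: 47000 nM

All three were tested in an ADME assay on MT4 cells (Homo sapiens) for cytotoxicity, read by MTT assay; on this read-out lower numbers stand for higher toxicity in this test and higher numbers for lower toxicity in this test. Compound 1 and compound 3 carry the same group on the carbonyl carbon and differ in their cores by methyl in place of chloro on an aromatic carbon; in this assay the step of a 1.0-fold lower number from compound 1 to compound 3 (0.01 log units; within the scatter) lies within the scatter. Compound 2 differs from compound 1 by 4-bromo-3-methylphenyl in place of 4-chloro-3-nitrophenyl on a carbonyl carbon, and in this assay this gave a 2.7-fold lower number from compound 1 to compound 2 (0.43 log units; beyond the scatter). Compound 4 `Cc1ccc(N(C(=O)c2ccc(Br)c(C)c2)C(=S)OCCN2C(=O)c3ccccc3C2=O)cc1` has not yet been measured; it differs from compound 3 by 4-bromo-3-methylphenyl in place of 4-chloro-3-nitrophenyl on a carbonyl carbon, the same change made at the same place. The step from compound 3 to compound 4 in this assay is expected to be about as large, a 2.6-fold lower number from compound 3 to compound 4 (0.42 log units; beyond the scatter), resting on a 2.7-fold lower number from compound 1 to compound 2 (0.43 log units; beyond the scatter). Compound 4 is therefore estimated to give roughly 18000 nM, between 8000 nM and 40000 nM.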

Compound 4, half-maximal cytotoxic concentration: > 100000 nM
Compound 4 gave a limit, no number; the forecaster's own chance of this, stated with the estimate: 5%; middle value at least 5.5-fold (0.74 log units) away from the limit.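

In this assay, as far as these compounds go, compound 4 gives > 100000 nM, which is a limit of the assay and not a number, so the true size of the steps to it remains unknown. The change to 4-bromo-3-methylphenyl on a carbonyl carbon gave an at least 2.1-fold higher number from compound 3 to compound 4 (0.32 log units; beyond the scatter), so its effect did not carry over from the core of compound 1 to the core of compound 3: the same change on two cores in this assay, a 2.7-fold lower number (0.43 log units; beyond the scatter) from compound 1 to compound 2 and an at least 2.1-fold higher number (0.32 log units; beyond the scatter) from compound 3 to compound 4, at least 5.6-fold (0.75 log units) apart, beyond the scatter of two such steps Likewise, methyl in place of chloro on an aromatic carbon gave an at least 5.5-fold higher number from compound 2 to compound 4 (0.74 log units; beyond the scatter), so that step also depends on the group on the carbonyl carbon, though this rests on a single set of four compounds: the same change on two cores in this assay, a 1.0-fold lower number (0.01 log units; within the scatter) from compound 1 to compound 3 and an at least 5.5-fold higher number (0.74 log units; beyond the scatter) from compound 2 to compound 4, at least 5.6-fold (0.75 log units) apart, beyond the scatter of two such steps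

The compounds shown leave open whether the change would behave the same way with a methoxy group or an amine in place of that methyl.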